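Swapping Methyl for Isopropyl on the Hydroxyurea Nitrogen

A few compounds are considered here, and "the series" means these few. Any claim that something is new, unique, unknown or untested is made for them only; others in the source may bear on it.

Of the compounds shown here, three sharing one core have been tested in a functional assay for inhibition of Polyunsaturated fatty acid 5-lipoxygenase (Homo sapiens); on this read-out higher numbers stand for an effect only at larger amounts of compound and lower numbers for an effect already at smaller amounts. Compound 1 `CN(O)C(=O)NCCSc1nc2ccccc2s1` gives 90 nM. Compound 2 `CC(C)N(O)C(=O)NCCSc1nc2ccccc2s1`, which carries isopropyl in place of methyl on an amide-type nitrogen, gives 130 nM. Compound 3 `CCOc1ccc2nc(SCCNC(=O)N(C)O)sc2c1`, which carries ethoxy in place of hydrogen on an aromatic carbon, gives 110 nM. Among these three numbers compound 3 sits in the middle, its nearest neighbour being compound 2 and its furthest compound 1, and all three lie within the scatter of one another, as the measured steps of a 1.4-fold higher number from compound 1 to compound 2 (0.16 log units; within the scatter) and a 1.2-fold higher number from compound 1 to compound 3 (0.09 log units; within the scatter) show.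

Compound 4 `CCOc1ccc2nc(SCCNC(=O)N(O)C(C)C)sc2c1` has not yet been measured. It differs from compound 3 by isopropyl in place of methyl on an amide-type nitrogen. Among the measured compounds shown here, the one measured step that bears on this change is a 1.4-fold higher number from compound 1 to compound 2 (0.16 log units; within the scatter), the same exchange of isopropyl for methyl, which stayed within the scatter. On that basis no step beyond the scatter is expected in this assay, only a slight drift, and the expected step is a 1.4-fold higher number from compound 3 to compound 4 (0.13 log units; within the scatter). The estimate for compound 4 is therefore 150 nM, with a range from 70 nM to 320 nM.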

Compound 4, half-maximal effective concentration: 390 nM
Compound 4: the middle estimate sits 2.6-fold (0.41 log units) below what was measured, outside the stated range (above it).
By their numbers in this assay, from the lowest: compounds 1, 3 and 2 (each within the scatter of the next); then compound 4.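

On the core carrying ethoxy, isopropyl in place of methyl on the amide-type nitrogen gives a step beyond the scatter in this assay (a 3.5-fold higher number from compound 3 to compound 4 (0.55 log units; beyond the scatter)), yet this step cannot be firmly separated from the smaller one seen for the same change on the core of compound 1: (the same change on two cores in this assay, a 1.4-fold higher number (0.16 log units; within the scatter) from compound 1 to compound 2 and a 3.5-fold higher number (0.55 log units; beyond the scatter) from compound 3 to compound 4, 2.5-fold (0.39 log units) apart, within the scatter of two such steps). Ethoxy in place of hydrogen on an aromatic carbon likewise gives a step beyond the scatter when isopropyl is already present (a 3.0-fold higher number from compound 2 to compound 4 (0.48 log units; beyond the scatter)), with the same caution against its counterpart on the methyl compounds: (the same change on two cores in this assay, a 1.2-fold higher number (0.09 log units; within the scatter) from compound 1 to compound 3 and a 3.0-fold higher number (0.48 log units; beyond the scatter) from compound 2 to compound 4, 2.5-fold (0.39 log units) apart, within the scatter of two such steps). Each change alone stayed within the scatter, whereas the two together in compound 4 give a number clearly apart from those of compounds 2 and 3, so the effect of either change may depend on the other, though these four compounds cannot establish that.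

On these data alone, it remains open how an ethyl or a tert-butyl group on that nitrogen would read with ethoxy on the core. Also open, as far as these compounds go, is whether a methoxy group or a chlorine atom in place of ethoxy would give a similar step alongside isopropyl.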